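Piperidinyl in place of cyclohexyl on an acylguanidine chain

The source may hold more compounds than are shown below. What is called first, only, known or untested is meant among the compounds shown, and "the series" means these compounds.

Compound 1 `COc1ccc(Br)cc1CCc1c(F)cccc1C(=O)/N=C(\N)NCCC1CCCCC1` stands without a value in a functional assay for antagonist activity at Melanocortin receptor 4 (Homo sapiens), read by cAMP accumulation; a lower number here means a stronger inhibitor, a higher number a weaker inhibitor: its entry reads "not determined" (no result reported), so no single number anchors it. Compound 2 `CCN(CC)CCCC(C)/N=C(\NC(=O)c1cccc(F)c1CCc1cc(Br)ccc1OC)Nc1ccccc1` is in the same position, with "not determined" (no result reported) in this assay. The one reported entry belongs to compound 3 `CCN(CC)CCCC(C)/N=C(/N)NC(=O)c1cccc(F)c1CCc1ccccc1Cl`, and it is a limit of this assay, not a number: compound 3 gives > 33000 nM. Among the measured compounds shown here, that limit is the only evidence on record, (the limit of > 33000 nM in this assay, at which 1 of the 3 values shown sits), and it shows that a compound of the shared core can sit beyond the measurable range.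

Compound 4 `COc1ccc(Br)cc1CCc1c(F)cccc1C(=O)/N=C(\N)NCC1CCNCC1` differs from compound 1 in one place: piperidin-4-yl in place of cyclohexylmethyl on a saturated chain carbon bound to an amine nitrogen. For the measured compounds named here, since no measured step connects any two of the compounds, the size and direction of this change cannot be read from data; the weak showing of compound 3 at its limit suggests the series tends toward weak inhibition. Compound 4 is therefore estimated at 20000 nM in this assay, with an expected range from 2000 nM to 100000 nM, and a substantial chance that only a limit is reported.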

Compound 4, half-maximal inhibitory concentration: 31 nM
Estimate against measurement, compound 4: 650-fold (2.81 log units) above, and the stated range ends above it.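

No new step can be read from this result: in this assay compound 4 gives 31 nM, but neither compound 1 nor any other compound shown offers a single number to set beside it. The compounds shown leave open how much of that value goes with piperidin-4-yl in place of cyclohexylmethyl.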